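The source may hold more compounds than are shown below. What is called first, only, known or untested is meant among the compounds shown, and "the series" means these compounds.

Notes on the triazene series. The numbers come from a functional assay on HeLa cells (Homo sapiens) for cytotoxicity, read by MTT assay, with a stated time of 72 h; on this read-out higher numbers stand for weaker inhibition and lower numbers for stronger inhibition. Compound 1 (`CC(=O)Oc1ccc(/C=C/C(=O)N(/N=N/c2ccc(Cl)c(C(F)(F)F)c2)c2ccc(Cl)c(C(F)(F)F)c2)cc1OC(C)=O`) stands at the weak end: in this assay compound 1 gives 43000 nM. Compound 2 (`O=C(c1ccccc1)N(/N=N/c1ccc([N+](=O)[O-])cc1Br)c1ccc([N+](=O)[O-])cc1Br`), which carries a benzoyl group on the triazene nitrogen and bromine on both aryl rings, gives 1530 nM in this assay. Compound 3 (`O=[N+]([O-])c1ccc(/N=N/Nc2ccc([N+](=O)[O-])cc2Cl)c(Cl)c1`), the unsubstituted triazene with chlorine in place of bromine, gives 3010 nM in this assay; this is the second highest of the three numbers, lying within the usual scatter of the value of compound 2 and well apart from compound 1.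

Compound 4 (`O=C(c1ccccc1)N(/N=N/c1ccc([N+](=O)[O-])cc1Cl)c1ccc([N+](=O)[O-])cc1Cl`) is not yet measured in this assay. It differs from compound 3 in one place: benzoyl in place of hydrogen on a nitrogen on an aromatic ring. Going by the values given here, no single-change pair among the measured compounds mirrors this step. The closest guidance is that compound 2, which also carries the benzoyl group, and compound 3, which does not, sit within the scatter of each other, so no step beyond the scatter is expected in this assay for compound 4, in either direction. The estimate for compound 4 is therefore 2200 nM (range 700 nM to 7000 nM), an expected step of a 1.4-fold lower number from compound 3 to compound 4 (0.14 log units; within the scatter).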

Compound 4, half-maximal inhibitory concentration: 590 nM
For compound 4 the middle estimate is 3.7-fold (0.57 log units) above the measured one; the whole stated range lies above it.
By their numbers in this assay, from the lowest: compound 4; then compounds 2 and 3 (each within the scatter of the next); then compound 1.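

Working from the hydrogen-bearing triazene, benzoyl in place of hydrogen on a nitrogen on an aromatic ring gives a 5.1-fold lower number from compound 3 to compound 4 (0.71 log units; beyond the scatter) in this assay, a modest step but the first single-change step in the series. The earlier compounds shown here could not isolate this change, as no measured pair differed in one place only; this pair shows that, with the rest of the structure held constant, the position accepts benzoyl and the number falls, with compound 4 at 590 nM. No measurement at hand bears on why the number falls at this position.

From the compounds shown here alone, it remains open whether the step depends on the carbonyl or on the aromatic ring of benzoyl: a benzyl group on the same nitrogen would separate the two, and a methyl group would show what a small group does there. The step also rests on a single pair, so whether it carries over to the other substitution patterns on the aryl rings, or to other acyl groups such as pivaloyl, is unsettled.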